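This account rests on a few compounds, and the source may have more. Where it says the series, first, only, none or still open, it means among the compounds named here.

Compound 2, with the structure `Cc1c(OCCCCOc2cccnc2)ccc(C(=O)CC(C)C)c1O`, is measured in a functional assay for binding affinity to metabotropic glutamate receptor 2 (Homo sapiens), read by GTPgammaS binding (a higher number here means that more compound is needed for the effect, a lower number that less compound is needed), at 1720 nM. Among the three measured compounds this is the second highest number: compound 1, with the structure `Cc1c(OCCCCOc2ccc(-n3cncn3)cc2)ccc(C(=O)CC(C)C)c1O`, gives 4240 nM in this assay, and compound 3, with the structure `CC(C)CC(=O)c1ccc(OCCCCOc2cccnc2)c(Br)c1O`, gives 575 nM. For the measured compounds named here, the one measured step within this set runs a 3.0-fold lower number from compound 2 to compound 3 (0.48 log units; beyond the scatter).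

Compound 4, with the structure `Cc1c(OCCCCSc2cccnc2)ccc(C(=O)CC(C)C)c1O`, differs from compound 2 in a different part of the molecule: (pyridin-3-yl)sulfanyl in place of (pyridin-3-yl)oxy on a saturated chain carbon, four bonds along the chain from an oxygen on an aromatic ring. No measured step touches this ether-to-thioether exchange, so the step from compound 2 to compound 3 offers no direct guide, and the data give no reason to expect a change beyond the usual scatter in either direction. The step is therefore expected to be about a 1.0-fold lower number from compound 2 to compound 4 (0.01 log units; within the scatter). For compound 4 the expected value in this assay is 1700 nM, with a likely range from 600 nM to 5000 nM.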

Compound 4, half-maximal effective concentration: 1090 nM
The estimate for compound 4 lay 1.6-fold (0.19 log units) above the measured number; the measured number falls inside the stated range.
By their numbers in this assay, from the lowest: compounds 3, 4 and 2 (each within the scatter of the next, the first and the last beyond it); then compound 1.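

Exchanging (pyridin-3-yl)oxy for (pyridin-3-yl)sulfanyl on the saturated chain carbon gives, in this assay, a 1.6-fold lower number from compound 2 to compound 4 (0.20 log units; within the scatter). For the compounds shown here, the earlier step concerned only bromo in place of methyl on an aromatic carbon, so this is the first reading at this position, and it shows that sulfur can take the place of oxygen here with no change that stands clear of the usual variation between repeat measurements. No separate measurement is available to explain this result.

As far as these compounds go, it remains open whether a (pyridin-3-yl)amino or (pyridin-3-yl)sulfonyl group at the same place would also stay this close to compound 2. From the compounds shown here alone, it is equally open whether the (pyridin-3-yl)sulfanyl group would give a similar result when combined with bromo in place of methyl, as in compound 3.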